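Returning to a direct biaryl link in the bile acid receptor series

A few compounds are considered here, and "the series" means these few. Any claim that something is new, unique, unknown or untested is made for them only; others in the source may bear on it.

Among the compounds with values here, compound 2, `COC(=O)/C=C/c1cccc(N(Cc2ccc(/C=C/c3cccc(F)c3)cc2)C(=O)NC(C)C)c1`, holds the lower of the two numbers so far in an assay on isolated protein with Bile acid receptor (Homo sapiens) as the target (on this read-out higher numbers stand for an effect only at larger amounts of compound and lower numbers for an effect already at smaller amounts), giving 467 nM. Compound 1, `COC(=O)/C=C/c1cccc(N(Cc2ccc(-c3cccc(OC)c3)cc2)C(=O)NC(C)C)c1`, gives 1370 nM in this assay. Within the data shown here, the single measured step, a 2.9-fold lower number from compound 1 to compound 2 (0.47 log units; beyond the scatter), replaced 3-methoxyphenyl with 2-(3-fluorophenyl)ethenyl on an aromatic carbon. Compound 3, `COC(=O)/C=C/c1cccc(N(Cc2ccc(-c3cccc(Cl)c3)cc2)C(=O)NC(C)C)c1`, reverses the direction of that change: 3-chlorophenyl in place of 2-(3-fluorophenyl)ethenyl on an aromatic carbon, with the new group sitting para to a large group. Among the measured compounds shown here, because the only step in hand, a 2.9-fold lower number from compound 1 to compound 2 (0.47 log units; beyond the scatter), favoured the ethenyl-linked group, a step back toward the number of compound 1 is expected, although the chlorine in compound 3 has no measured counterpart, so the size is uncertain. The estimate is a moderate rise, a 2.1-fold higher number from compound 2 to compound 3 (0.33 log units; beyond the scatter). Compound 3 is therefore expected to give about 1000 nM in this assay, within a range from 400 nM to 2500 nM.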

Compound 3, half-maximal effective concentration: 1400 nM
Compound 3: the middle estimate sits 1.4-fold (0.15 log units) below what was measured; the measured number falls inside the stated range.
By their numbers in this assay, from the lowest: compound 2; then compounds 1 and 3 (each within the scatter of the next).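

Replacing the 2-(3-fluorophenyl)ethenyl group with 3-chlorophenyl in this assay gives a 3.0-fold higher number from compound 2 to compound 3 (0.48 log units; beyond the scatter), so the gain seen with the ethenyl-linked group is lost at this position. Exchanging chloro for methoxy on the directly attached phenyl ring gives a 1.0-fold higher number from compound 1 to compound 3 (0.01 log units; within the scatter), which lies within the scatter, so among the compounds shown only compound 2, with its ethenyl-linked group, stands apart from the other two. Nothing available here accounts for these differences.

From the compounds shown here alone, the step from compound 2 to compound 3 changes the ethenyl link and the halogen together, so it remains open which of the two goes with the lower number of compound 2. A 3-fluorophenyl group or a 2-(3-chlorophenyl)ethenyl group at this position would separate the two, and an ethyl link or an amine on the outer ring also remains to be read.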